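Adenosine receptor series: amine variation on the shared core

The source may report more compounds than this note shows. Statements on the series, on what has been measured and on what is new or still open speak of the compounds shown alone.

Measured so far:
compound 1 `CCCC(=O)Nc1ncc(-c2cccc(Cl)c2)c(-c2ccccc2)n1` 106 nM
compound 2 `Clc1cccc(-c2cnc(NC3CCCC3)nc2-c2ccccc2)c1` 94 nM

In an assay on CHO cells for displacement of a labelled ligand from adenosine receptor A1 (Homo sapiens), read by scintillation counting, with a stated time of 1 h (a lower number here means a stronger inhibitor, a higher number a weaker inhibitor), compound 2 gives the lower of the two numbers, with compound 1 close by: the step of a 1.1-fold lower number from compound 1 to compound 2 (0.05 log units; within the scatter) is within the scatter, so the two cannot be ordered. Compound 3 `OCCCNc1ncc(-c2cccc(Cl)c2)c(-c2ccccc2)n1` carries the change (3-hydroxypropyl in place of cyclopentyl on a nitrogen on an aromatic ring), cut one bond further out cyclopentylamino to (3-hydroxypropyl)amino. Among the measured compounds shown here, no measured step covers this exchange; the single step from compound 1 to compound 2 involves a different group and was within the scatter. A moderate rise is therefore expected only tentatively, with a wide range. For compound 3 the estimated number is 300 nM (range 90 nM to 1000 nM), an expected step of a 3.2-fold higher number from compound 2 to compound 3 (0.50 log units; beyond the scatter).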

Compound 3, inhibition constant: 59 nM
Compound 3: the middle estimate sits 5.1-fold (0.71 log units) above what was measured; the measured number lies below the stated range.
By their numbers in this assay, from the lowest: compounds 3, 2 and 1 (each within the scatter of the next).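

In this assay, an open chain carrying a hydrogen-bond donor and acceptor, 3-hydroxypropyl, on a nitrogen on an aromatic ring cannot be told apart from the ring of carbon only, cyclopentyl (a 1.6-fold lower number from compound 2 to compound 3 (0.20 log units; within the scatter)). It also cannot be told apart from propylcarbonyl (a 1.8-fold lower number from compound 1 to compound 3 (0.25 log units; within the scatter)). No measurement offers a cause for this.

Open, as far as these compounds go, is whether a longer chain, a carboxylic acid or an amine in place of 3-hydroxypropyl would stay within the scatter of these three compounds. Also open, from the compounds shown here alone, is whether plain propyl would do so.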